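The source may report more compounds than this note shows. Statements on the series, on what has been measured and on what is new or still open speak of the compounds shown alone.

In a functional assay on HCT-116 cells (Homo sapiens) for antiproliferative activity, read by MTT assay, with a stated time of 72 h (on this read-out lower numbers stand for stronger inhibition and higher numbers for weaker inhibition), three compounds on a shared core have been measured. Compound 1 (`Nc1nc(N)c2cc(CSC(=S)N3CCN(C4CCCCC4)CC3)ccc2n1`) gives 8400 nM, compound 2 (`Nc1nc(N)c2cc(CSC(=S)N3CCN(c4ccccc4)CC3)ccc2n1`) gives 4120 nM, and compound 3 (`Nc1nc(N)c2cc(CSC(=S)N3CCN(c4ccc(O)cc4)CC3)ccc2n1`) gives 5980 nM. The number for compound 3 lies between the other two, and neither gap leaves the scatter: a 1.4-fold lower number from compound 1 to compound 3 (0.15 log units; within the scatter), and a 1.5-fold higher number from compound 2 to compound 3 (0.16 log units; within the scatter). Only a 2.0-fold lower number from compound 1 to compound 2 (0.31 log units; beyond the scatter) goes beyond the scatter, and it is modest.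

The next compound is compound 4 (`COc1ccc(N2CCN(C(=S)SCc3ccc4nc(N)nc(N)c4c3)CC2)cc1`). Its difference is methyl in place of hydrogen on an oxygen on an aromatic ring, so that 4-hydroxyphenyl becomes 4-methoxyphenyl. Among the compounds with values here, no measured pair tests this exact change. The closest evidence is the step that introduced the hydroxy, a 1.5-fold higher number from compound 2 to compound 3 (0.16 log units; within the scatter), which stayed within the scatter. A step beyond the scatter is therefore not expected in this assay, and no direction can be favoured. The expected change is small, a 1.2-fold lower number from compound 3 to compound 4 (0.08 log units; within the scatter). Compound 4 is estimated at 5000 nM, with an expected range of 2500 nM to 10000 nM.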

Compound 4, half-maximal inhibitory concentration: 2270 nM
Beside the measured number, compound 4's estimate is 2.2-fold (0.34 log units) above it; measured number below the stated range.
By their numbers in this assay, from the lowest: compounds 4, 2, 3 and 1 (each within the scatter of the next, the first and the last beyond it).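

In this assay, the oxygen on the aromatic ring proves to be a place where a single added methyl registers: a 2.6-fold lower number from compound 3 to compound 4 (0.42 log units; beyond the scatter) is beyond the scatter, whereas the earlier step that introduced the hydroxy, a 1.5-fold higher number from compound 2 to compound 3 (0.16 log units; within the scatter), was not. The methoxy nevertheless does not clearly separate from the unsubstituted phenyl, since a 1.8-fold lower number from compound 2 to compound 4 (0.26 log units; within the scatter) stays within the scatter, so the data show a difference between hydroxy and methoxy but none between either of them and hydrogen. Against cyclohexyl on the amine nitrogen in the ring, 4-methoxyphenyl gives a 3.7-fold lower number from compound 1 to compound 4 (0.57 log units; beyond the scatter), which is beyond the scatter but modest.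

The data shown offer no measurement that explains why the methyl on this oxygen counts. As far as these compounds go, whether a longer chain such as ethoxy, or an amine or a carboxylic acid in place of the methoxy, would follow the same trend remains open.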